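Hydroxymethyl for ethoxy on the coumarin-type core

A few compounds are considered here, and "the series" means these few. Any claim that something is new, unique, unknown or untested is made for them only; others in the source may bear on it.

Compound 1 `CCOc1cc(=O)oc2cc(OCc3cccc(Cl)c3)ccc12` gives 115 nM in an assay on isolated protein (strain Sprague-Dawley) for inhibition of Amine oxidase [flavin-containing] B (Rattus norvegicus), read by spectrophotometry, with a stated time of 5 min (a higher number here means a weaker inhibitor, a lower number a stronger inhibitor), the highest of the two single numbers measured here, with compound 2 as its nearest neighbour. For the measured compounds named here, compound 2 `CC(=O)COc1cc(=O)oc2cc(OCc3cccc(Cl)c3)ccc12` gives 26.9 nM, and the step of a 4.3-fold lower number from compound 1 to compound 2 (0.63 log units; beyond the scatter) is the only one-place change measured so far. Going by the values given here, compound 3 `NC(=O)COc1cc(=O)oc2cc(OCc3cccc(Cl)c3)ccc12` gives 3.1 nM; 3.31 nM (2 entries); the repeated entries the several entries of compound 3 in this assay, 3.1 nM; 3.31 nM (2 entries) agree closely, and its numbers stand well below those of compound 1 and compound 2, though no single-place step connects it to either.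

Compound 4 `O=c1cc(CO)c2ccc(OCc3cccc(Cl)c3)cc2o1` differs from compound 1 by hydroxymethyl in place of ethoxy on an aromatic carbon. Among the compounds with values here, no measured step matches this change directly: the step from compound 1 to compound 2 altered the chain bound to the oxygen on the aromatic ring but kept that oxygen, whereas here the ethoxy leaves altogether and a hydroxymethyl enters. The step from compound 1 to compound 2 was modest and beyond the scatter, and compound 3, carrying a hydrogen-bond donor, sits lowest of all; a modest step toward a lower number is therefore expected, though with wide uncertainty. For compound 4 a number of 35 nM is estimated, expected between 8 nM and 150 nM. The expected step is a 3.3-fold lower number from compound 1 to compound 4 (0.52 log units; beyond the scatter).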

Compound 4, half-maximal inhibitory concentration: 5.25 nM
Compound 4: middle estimate off by 6.7-fold (0.82 log units), on the high side; measured number below the stated range.
By their numbers in this assay, from the lowest: compound 4; then compound 2; then compound 1.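

In this assay, the place opposite the ring oxygen does not need an oxygen bound directly to the aromatic carbon: hydroxymethyl in place of ethoxy gives a 22-fold lower number from compound 1 to compound 4 (1.34 log units; beyond the scatter), a large step, whereas changing the chain while keeping that oxygen gave the modest 4.3-fold lower number from compound 1 to compound 2 (0.63 log units; beyond the scatter). Hydroxymethyl also outdoes the 2-oxopropoxy group, with a 5.1-fold lower number from compound 2 to compound 4 (0.71 log units; beyond the scatter), so at this place the low numbers do not depend on keeping an oxygen-linked chain with a carbonyl. Compound 4 thereby reaches the low range otherwise seen here only with an oxygen-linked chain, and its value of 5.25 nM is set without any claim of order against the values for its closest neighbour in number: the several entries of compound 3 in this assay, 3.1 nM; 3.31 nM (2 entries).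

The single change removes the ring-bound oxygen, shortens the group from 3 heavy atoms to 2 and adds 1 hydrogen-bond donor, and these three differences cannot be separated with the compounds shown. Methoxymethyl, aminomethyl or a longer chain such as 2-hydroxyethyl at the same place would begin to pull them apart.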